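Inverting One Stereocentre of Compound 1

The source may report more compounds than this note shows. Statements on the series, on what has been measured and on what is new or still open speak of the compounds shown alone.

Compound 1 `CC(C)=C1CC[C@]2(C)CC[C@]3(O[C@H](C[C@H]3C)C[C@]3(C)O[C@H]3C1=O)O2`: > 50000 nM
Compound 2 `CC(=O)O[C@@]1(C)CCC(=O)[C@@H](C)CCC[C@]2(C)O[C@H]2C(=O)C(=C(C)C)CC1`: 43700 nM

Both compounds were tested in a functional assay on DU-145 cells (Homo sapiens) for cytotoxicity, read by MTT assay, with a stated time of 24 h; on this read-out lower numbers stand for stronger inhibition and higher numbers for weaker inhibition. In this assay compound 1 gives > 50000 nM, and this is a limit of the assay, not a number. It is the limit of > 50000 nM in this assay, at which 1 of the 2 values shown sits. Compound 2 is not directly related to compound 1 by a single change. Compound 2 gives a numerical value of 43700 nM.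

The next compound to be tested is compound 3 `CC(C)=C1CC[C@]2(C)CC[C@]3(O[C@H](C[C@@H]3C)C[C@]3(C)O[C@H]3C1=O)O2`. Its relation to compound 1 is the two compounds have the same atoms and bonds and differ only in configuration as drawn: 1 of 6 stereo elements differ; a stereocentre at a saturated ring carbon is drawn R in compound 1 and S in compound 3. The two have the same atoms and bonds, and a stereocentre at a saturated ring carbon is drawn R in compound 1 and S in compound 3.

Within the data shown here, no measured pair shows what such an inversion does in this assay, so no step beyond the scatter is expected in either direction. The expected step is a number no higher from compound 1 to compound 3 (the limit leaves the size open). This expectation rests on compound 1 at > 50000 nM, and compound 3 may well be reported only as a limit too. For compound 3 the estimated value is 50000 nM, with an expected range from 25000 nM to 100000 nM.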

Compound 3, half-maximal inhibitory concentration: > 50000 nM
Compound 3 ended at the assay's limit; the forecaster's own chance of this, stated with the estimate: 65%; the middle value sits exactly at the limit.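

In this assay compound 3 gives > 50000 nM as a limit of the assay, not a number. No step can be read between compound 1 and compound 3, because both stand at that limit: the limit of > 50000 nM in this assay, at which 2 of the 3 values shown sit. As far as these compounds go, what inverting this stereocentre at a saturated ring carbon does in this assay therefore remains open.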